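Imidazoline series: aryl variation at the amidine carbon

A few compounds are considered here, and "the series" means these few. Any claim that something is new, unique, unknown or untested is made for them only; others in the source may bear on it.

Compound 1 `Nc1cccc(C2=NC(c3ccc(F)cc3)(c3ccc(F)cc3)CN2)c1`: in an assay on LM cells for displacement of a labelled ligand from Neuropeptide Y receptor type 5 (Homo sapiens) (on this read-out higher numbers stand for weaker inhibition and lower numbers for stronger inhibition), compound 1 gives 300 nM.
Compound 2 `Fc1ccc(C2(c3ccc(F)cc3)CNC(c3cccs3)=N2)cc1`: in this assay compound 2 gives 54 nM.

Of the two measured compounds, compound 2 carries the lower number, and the gap to compound 1 lies beyond the scatter. Within the data shown here, the only measured step is the exchange at the carbon with a double bond to nitrogen: a 5.6-fold lower number from compound 1 to compound 2 (0.74 log units; beyond the scatter).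

Compound 3 `N#Cc1cccc(C2=NC(c3ccc(F)cc3)(c3ccc(F)cc3)CN2)n1` differs from compound 2 at the same position: 6-cyanopyridin-2-yl in place of thiophen-2-yl on a carbon with a double bond to nitrogen. Among the measured compounds shown here, no measured pair covers this exact exchange. For the measured compounds named here, the one step that bears on it, from compound 1 to compound 2, shows that a five-membered aromatic ring at this carbon gave a lower number than a six-membered one bearing an amino group. Returning to a six-membered aromatic ring, now with a ring nitrogen and a nitrile, is therefore expected to move the number back toward that of compound 1, though the size cannot be fixed from a single step; the expected step is a 2.2-fold higher number from compound 2 to compound 3 (0.35 log units; beyond the scatter). For compound 3 the estimate in this assay is 120 nM, with a range from 40 nM to 400 nM.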

Compound 3, half-maximal inhibitory concentration: 39 nM
Compound 3: middle estimate off by 3.1-fold (0.49 log units), on the high side, and the stated range ends above it.
By their numbers in this assay, from the lowest: compounds 3 and 2 (each within the scatter of the next); then compound 1.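

In this assay, the exchange of thiophen-2-yl for 6-cyanopyridin-2-yl is a 1.4-fold lower number from compound 2 to compound 3 (0.14 log units; within the scatter), so at this carbon a six-membered aromatic ring with a nitrile in compound 3 reads the same as the five-membered ring of compound 2. The 3-aminophenyl of compound 1 stands apart from both, with a 7.7-fold lower number from compound 1 to compound 3 (0.89 log units; beyond the scatter) alongside a 5.6-fold lower number from compound 1 to compound 2 (0.74 log units; beyond the scatter), so a six-membered aromatic ring at this position does not by itself go with the higher number, and compound 3 is the case against that reading of the first step. No supporting data bear on why the two rings read alike or why compound 1 stands apart.

Compound 1 and compound 3 differ in the ring nitrogen and in the substituent at once, so these two changes cannot be separated with the compounds shown. Plain phenyl, pyridin-2-yl without the nitrile and 3-cyanophenyl at the same carbon would pull them apart, and it remains open how any of these stands against compound 2 and compound 3 on the shared core.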